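The compounds below may be only part of what the source reports. "The series", "measured", "known", "first", "only" and "open" are said of these compounds alone.

Readings in a physicochemical assay for solubility, read by HPLC, in phosphate buffer, measured as kinetic solubility, at pH 7.4 (on this read-out lower numbers stand for lower solubility and higher numbers for higher solubility), so far:
compound 1 `CCC(=O)c1cc(-c2ccc(S(N)(=O)=O)cc2)n(-c2ccc(Cl)cc2)n1` gives 41900 nM
compound 2 `CC(=O)c1cc(-c2ccc(S(N)(=O)=O)cc2)n(-c2ccc(Cl)cc2)n1` gives 86800 nM
compound 3 `NS(=O)(=O)c1ccc(-c2cc(C(=O)CC3CCCC3)nn2-c2ccc(Cl)cc2)cc1` gives 2600 nM

Compound 3 holds the lowest number of the three. The next structure, compound 4 `NS(=O)(=O)c1ccc(-c2cc(C(=O)N3CCCC3)nn2-c2ccc(Cl)cc2)cc1` has pyrrolidin-1-yl in place of cyclopentylmethyl on a carbonyl carbon.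

The closest measured evidence is a 16-fold lower number from compound 1 to compound 3 (1.21 log units; beyond the scatter) and a 33-fold lower number from compound 2 to compound 3 (1.52 log units; beyond the scatter) with both steps large and both bringing in cyclopentyl on a saturated chain carbon bound to a carbonyl carbon. The step of a 2.1-fold higher number from compound 1 to compound 2 (0.32 log units; beyond the scatter) is modest by comparison. In these three compounds the number falls as the group on the carbonyl carbon grows, and none goes against this. Among the compounds with values here, no measured step replaces a carbon-only ring with a ring holding nitrogen, so the evidence is indirect. Compound 4 keeps a five-membered ring, so only part of the large falls is expected to be recovered. In this assay the expected change is a 5.8-fold higher number from compound 3 to compound 4 (0.76 log units; beyond the scatter) and this is estimated to lie beyond the scatter. For compound 4 the estimated value is 15000 nM with an expected range from 5000 nM to 50000 nM in this read-out.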

Compound 4, solubility: 57900 nM
Compound 4: middle estimate off by 3.9-fold (0.59 log units), on the low side, outside the stated range (above it).
By their numbers in this assay, from the lowest: compound 3; then compounds 1, 4 and 2 (each within the scatter of the next, the first and the last beyond it).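

In this assay, a five-membered ring on the carbonyl carbon does not by itself go with a low number: pyrrolidin-1-yl in place of cyclopentylmethyl gives a 22-fold higher number from compound 3 to compound 4 (1.35 log units; beyond the scatter). The pyrrolidin-1-yl compound also stands level with the compounds carrying the smaller groups, with a 1.5-fold lower number from compound 2 to compound 4 (0.18 log units; within the scatter) and a 1.4-fold higher number from compound 1 to compound 4 (0.14 log units; within the scatter), so compound 4 goes against the earlier trend of the number falling as the group on the carbonyl carbon grows. Nothing measured here explains this step.

The compounds shown do not separate the effect of the ring nitrogen from that of removing the chain carbon bound to the carbonyl carbon. Cyclopentyl bound directly to the carbonyl carbon would address that question, while a piperidine or morpholine amide would test how far the trend seen with pyrrolidin-1-yl extends.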